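A few compounds are considered here, and "the series" means these few. Any claim that something is new, unique, unknown or untested is made for them only; others in the source may bear on it.

Three compounds of the series have been run in an assay on isolated protein for inhibition of Leucine-rich repeat serine/threonine-protein kinase 2 (Homo sapiens), read by TR-FRET and LanthaScreen, with stated times of 50 min and 30 min, in the presence of a further agent that is not named here; on this read-out lower numbers stand for stronger inhibition and higher numbers for weaker inhibition. Compound 1 `Cc1nn(C2COC2)cc1Nc1nc(N)c2c(C#N)c(N3CCC[C@H]3C)n(C)c2n1` gives 38 nM, compound 2 `Cc1n[nH]cc1Nc1nc(N)c2c(C#N)c(N3CCC[C@H]3C)n(C)c2n1` gives 42 nM, and compound 3 `Cc1nn(C)cc1Nc1nc(N)c2c(C#N)c(N3CCC[C@H]3C)n(C)c2n1` gives 38 nM. The three differ from one another only in what sits on an aromatic nitrogen: oxetan-3-yl, hydrogen or methyl. Among the compounds with values here, the steps of a 1.1-fold higher number from compound 1 to compound 2 (0.04 log units; within the scatter), no change at the digits printed from compound 1 to compound 3 (within the scatter) and a 1.1-fold lower number from compound 2 to compound 3 (0.04 log units; within the scatter) all stay within the scatter, so compound 3 stands level with compound 1 and no compound of the three separates from the others on this read-out. Exchanging the group on that aromatic nitrogen has left the number essentially untouched.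

Compound 4 `C[C@@H]1CCCN1c1c(C#N)c2c(N)nc(Nc3cn(C)nc3C(F)(F)F)nc2n1C` differs from compound 3 in another place: trifluoromethyl in place of methyl on an aromatic carbon. Within the data shown here, none of the measured steps touches an aromatic carbon of that ring; all three concern the aromatic nitrogen, and they speak to a different position. Among the measured compounds shown here, no measured step therefore bears directly on the change from compound 3 to compound 4, and the expectation rests on the rest of the structure being identical. With the remainder of the molecule unchanged, the step of a 1.4-fold higher number from compound 3 to compound 4 (0.16 log units; within the scatter) is expected to be modest, without a clear direction beyond the scatter. Compound 4 is estimated at 55 nM, within a range from 15 nM to 200 nM.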

Compound 4, half-maximal inhibitory concentration: 508 nM
Compound 4: the middle estimate sits 9.2-fold (0.97 log units) below what was measured; measured number outside the range, above it.
By their numbers in this assay, from the lowest: compounds 1, 3 and 2 (each within the scatter of the next); then compound 4.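

Within the data shown here, the aromatic carbon of the five-membered ring behaves differently from the aromatic nitrogen, where all three exchanges stayed within the scatter: trifluoromethyl in place of methyl on this carbon gives a 13-fold higher number from compound 3 to compound 4 (1.13 log units; beyond the scatter) and is the first change to move the number beyond the scatter. The wider exchanges of the whole ring substituent read the same way, with a 12-fold higher number from compound 2 to compound 4 (1.08 log units; beyond the scatter) and a 13-fold higher number from compound 1 to compound 4 (1.13 log units; beyond the scatter) both large, so compound 4 stands apart from all three earlier compounds, which remain together within the scatter of one another. Nothing available here accounts for this large step, and the numbers record its size and direction only.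

On these data alone, with only methyl and trifluoromethyl to compare on this carbon, it remains open whether a hydrogen, a chlorine, an ethyl or a difluoromethyl group there would stay close to compound 3 or fall nearer compound 4. As far as these compounds go, it is also open whether trifluoromethyl on this carbon would give a step of the same size with hydrogen or oxetan-3-yl on the ring nitrogen in place of methyl.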